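Dropping the Fluorine from the Core of Compound 1

The source may hold more compounds than are shown below. What is called first, only, known or untested is meant among the compounds shown, and "the series" means these compounds.

Of the compounds shown here, three that share a core have so far been tested in a functional assay on the whole organism with Mus musculus as the target, with a stated time of 15 min; on this read-out lower numbers stand for an effect already at smaller amounts and higher numbers for an effect only at larger amounts of compound. Compound 1 `Cc1sc2c(F)cccc2c1C1C=CN=CN1` gives 10 mg/kg in this assay. Compound 2 `Cc1sc2c(c1C1C=CN=CN1)CCC2` gives 10 mg/kg, a value level with that of compound 1 within the usual scatter, so no order between these two can be read. Compound 3 `Cc1sc(C2C=CN=CN2)c(C)c1C` gives 30 mg/kg; its number is higher than that of compound 1 by a margin beyond the scatter, so compound 1 and compound 2 together hold the lowest numbers of the three. Going by the values given here, no pair of measured compounds differs in only one place, so no measured step shows what a single change does on this read-out.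

Compound 4 `Cc1sc2ccccc2c1C1C=CN=CN1` has not yet been tested. It differs from compound 1 in one place: hydrogen in place of fluoro on an aromatic carbon. Nothing in the measured set speaks to a change of this kind, so the expectation rests on compound 1 alone. The step of no change at the digits printed from compound 1 to compound 4 (within the scatter) is expected to stay within the scatter, with no clear direction. Compound 4 is estimated at 10 mg/kg, with a range from 5 mg/kg to 30 mg/kg.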

Compound 4, minimum effective dose: 3 mg/kg
Estimate against measurement, compound 4: 3.3-fold (0.52 log units) above, and the stated range ends above it.
By their numbers in this assay, from the lowest: compound 4; then compounds 1 and 2 (each within the scatter of the next); then compound 3.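

Going by these compounds alone, until now no single change had been measured on this read-out, and this is the first direct look at what one swap does. In this assay, hydrogen in place of fluoro on an aromatic carbon gives a 3.3-fold lower number from compound 1 to compound 4 (0.52 log units; beyond the scatter) and is a modest step, yet one beyond the scatter. At this place on the six-membered aromatic ring of carbon only, the fluoro is therefore not needed for an effect in the mouse, and the compound without it acts at a smaller dose, while nothing at hand explains why the number falls.

Only fluoro and hydrogen are shown at this place, and a single step cannot tell how other groups, such as chloro, a methoxy group or an amine, would compare with either of them. Also open, going by these compounds, is whether the same swap at the other carbons of this ring would give a step of similar size or direction, and whether a lower number here would hold at times other than the one stated for this test.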